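Dropping the Chlorine from the Anilide Ring

The compounds below may be only part of what the source reports. "The series", "measured", "known", "first", "only" and "open" are said of these compounds alone.

Within the data shown here, compound 2 `O=C(CN1CCN(c2nnc(Cc3ccccc3)c3ccccc23)CC1)Nc1ccc(F)c(Cl)c1` gives the lower of the two numbers so far in a functional assay on HT-29 cells (Homo sapiens) for cytotoxicity, read by MTT assay, with a stated time of 72 h (a higher number here means a weaker inhibitor, a lower number a stronger inhibitor), with 13300 nM. Compound 1 `Cc1ccc(F)cc1NC(=O)CN1CCN(c2nnc(Cc3ccccc3)c3ccccc23)CC1` gives 171000 nM. Compound 3 `O=C(CN1CCN(c2nnc(Cc3ccccc3)c3ccccc23)CC1)Nc1cccc(F)c1` carries 3-fluorophenyl in place of 3-chloro-4-fluorophenyl on an amide-type nitrogen. Among the measured compounds shown here, the only measured step that bears on this is a 13-fold lower number from compound 1 to compound 2 (1.11 log units; beyond the scatter), also a change of the aryl group on the amide nitrogen; it was large, but it does not test the chlorine on its own. A modest weakening is therefore expected: a 2.3-fold higher number from compound 2 to compound 3 (0.35 log units; beyond the scatter). Compound 3 is estimated at 30000 nM, within 10000 nM to 100000 nM.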

Compound 3, half-maximal inhibitory concentration: 95000 nM
Beside the measured number, compound 3's estimate is 3.2-fold (0.50 log units) below it; measured number inside the range.
By their numbers in this assay, from the lowest: compound 2; then compounds 3 and 1 (each within the scatter of the next).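

The change from 3-chloro-4-fluorophenyl to 3-fluorophenyl gives a 7.1-fold higher number from compound 2 to compound 3 (0.85 log units; beyond the scatter) in this assay, so most of what compound 2 gained over compound 1 is lost. Going the other way, the change of methyl to hydrogen gives a 1.8-fold lower number from compound 1 to compound 3 (0.26 log units; within the scatter), so the methyl in compound 1 shows no effect beyond the scatter. No measurement here explains either step.

The numbers in the two group names also show that the fluorine sits differently, so the loss of chlorine is not tested alone. As far as these compounds go, how a bromine or a methoxy group in place of the chlorine would read remains open.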